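This account rests on a few compounds, and the source may have more. Where it says the series, first, only, none or still open, it means among the compounds named here.

Working notes on the salicylanilide pair.

Two compounds have numbers in an ADME assay on MONO-MAC-6 cells (Homo sapiens) for cytotoxicity, read by MTT assay, with a stated time of 16 h; a higher number here means a weaker inhibitor, a lower number a stronger inhibitor. Compound 1 `O=C(Nc1ccc(C(F)(F)F)cc1)c1cc(Br)ccc1O` carries a bromo on the phenol ring and a trifluoromethyl on the aniline side; in this assay compound 1 gives 7600 nM. Compound 2 `O=C(c1ccccc1)c1ccc(NC(=O)c2cc(Cl)ccc2O)cc1` carries a chloro on the phenol ring and a benzoyl on the aniline side; in this assay compound 2 gives 48000 nM. Compound 2 therefore stands at the highest of the two numbers, and the gap down to compound 1 lies beyond the scatter; the two compounds differ on both sides of the amide, so the values alone do not tell which side carries the difference.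

Compound 3 `O=C(c1ccccc1)c1ccc(NC(=O)c2cc(Br)ccc2O)cc1` is not yet measured. It differs from compound 2 by bromo in place of chloro on an aromatic carbon, the aniline side being kept as in compound 2. Among the compounds with values here, no measured step isolates this exchange. The expectation for the step from compound 2 to compound 3 is a small one, a 1.4-fold lower number from compound 2 to compound 3 (0.14 log units; within the scatter), toward a lower number but likely within the scatter. Compound 3 is accordingly expected at about 35000 nM, with a range of 15000 nM to 80000 nM.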

Compound 3, half-maximal inhibitory concentration: 21800 nM
Beside the measured number, compound 3's estimate is 1.6-fold (0.21 log units) above it; low and high end bracket the measured number.
By their numbers in this assay, from the lowest: compound 1; then compound 3; then compound 2.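

With the benzoyl aniline side held constant, the exchange of 5-chloro-2-hydroxyphenyl for 5-bromo-2-hydroxyphenyl can now be read on its own in this assay: bromo in place of chloro, para to the hydroxy group, gives a 2.2-fold lower number from compound 2 to compound 3 (0.34 log units; beyond the scatter). With the bromo held constant, the aniline side can be read on its own as well: benzoyl in place of trifluoromethyl gives a 2.9-fold higher number from compound 1 to compound 3 (0.46 log units; beyond the scatter), so a single change on either side of the amide can move the number in this assay beyond the scatter. The data in hand offer no measured basis for explaining either step.

From the compounds shown here alone, each exchange is read only once, so it remains open whether bromo in place of chloro would give a step of similar size and direction with trifluoromethyl on the aniline side. Also open, going by these compounds, is how the number responds to a nitrile or a methoxy group at the position now holding bromo, or to an amine or a carboxylic acid in place of benzoyl on the aniline side.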